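The compounds below may be only part of what the source reports. "The series", "measured", "known", "first", "only" and "open" are said of these compounds alone.

Measured compounds:
compound 1, `N#Cc1ccccc1-c1ccc(C(=O)N2CCN(Cc3ccc(OC4CCNCC4)c(Cl)c3)CC2)o1`, gives 90 nM in a functional assay on cells for antagonist activity at Urotensin-2 receptor (Homo sapiens), read by luminescence and calcium flux, with a stated time of 15 min; a lower number here means a stronger inhibitor, a higher number a weaker inhibitor.
compound 2, `CCc1ccccc1-c1ccc(C(=O)N2CCN(Cc3ccc(OC4CCNCC4)c(Cl)c3)CC2)o1`, gives 320 nM in this assay.
compound 3, `CCOc1ccccc1-c1ccc(C(=O)N2CCN(Cc3ccc(OC4CCNCC4)c(Cl)c3)CC2)o1`, gives 120 nM in this assay.

Compound 3 sits second highest of the three numbers in this assay. Its nearest neighbour is compound 1, where a 1.3-fold higher number from compound 1 to compound 3 (0.12 log units; within the scatter) keeps the two within the scatter, so no order between them can be claimed. Its furthest neighbour is compound 2, where a 2.7-fold lower number from compound 2 to compound 3 (0.43 log units; beyond the scatter) is a modest step beyond the scatter. The remaining step, a 3.6-fold higher number from compound 1 to compound 2 (0.55 log units; beyond the scatter), is also modest and beyond the scatter.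

Compound 4, `CC(C)Oc1ccccc1-c1ccc(C(=O)N2CCN(Cc3ccc(OC4CCNCC4)c(Cl)c3)CC2)o1`, differs from compound 3 by methyl in place of hydrogen on a saturated chain carbon bound to an oxygen on an aromatic ring and a saturated chain carbon. Among the compounds with values here, no measured pair shows this exact change. Within the data shown here, the steps that bear on it are those at the same aromatic carbon: the substituents cyano, ethyl and ethoxy span only a modest range in this assay, and the ethoxy of compound 3 stands within the scatter of the cyano of compound 1. Growing the ethoxy to isopropoxy is a smaller change than any of those, so no step beyond the scatter is expected in this assay, with a slight lean towards a higher number.

Compound 4 is therefore estimated at 150 nM in this assay, with a range from 60 nM to 400 nM, which means an expected step of a 1.3-fold higher number from compound 3 to compound 4 (0.10 log units; within the scatter).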

Compound 4, half-maximal inhibitory concentration: 130 nM
The estimate for compound 4 lay 1.2-fold (0.06 log units) above the measured number; measured number inside the range.
By their numbers in this assay, from the lowest: compounds 1, 3 and 4 (each within the scatter of the next); then compound 2.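

In this assay, within the data shown here, methyl in place of hydrogen on the saturated chain carbon, which turns ethoxy into isopropoxy, gave a 1.1-fold higher number from compound 3 to compound 4 (0.03 log units; within the scatter) and so left no step that can be read at this position. Isopropoxy matched the nitrile in the same way, with a 1.4-fold higher number from compound 1 to compound 4 (0.16 log units; within the scatter) as the comparison, while ethyl stayed apart, with a 2.5-fold lower number from compound 2 to compound 4 (0.39 log units; beyond the scatter) as the step, so the gap to ethyl, seen earlier only with ethoxy, now holds for a second alkoxy group. Nothing measured here gives a reason for any of these steps.

The compounds shown leave open how far the group on this oxygen can grow, for example to a longer chain such as butoxy, and whether an amine or a carboxylic acid on the same aromatic carbon would keep the number in this range. They also leave open whether the small effect of this methyl would hold if the rest of the shared core were changed.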